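The compounds below may be only part of what the source reports. "The series", "measured", "known", "first", "only" and "open" are said of these compounds alone.

Measured in a functional assay on M14 cells (Homo sapiens) for cytotoxicity, read by resazurin assay, with a stated time of 72 h; on this read-out lower numbers stand for stronger inhibition and higher numbers for weaker inhibition:
compound 1 `COc1cc(/C=C/C(=O)OCCCCCCO[N+](=O)[O-])ccc1O`: > 50000 nM
compound 2 `O=C(/C=C/c1ccc(OCCCCCCO[N+](=O)[O-])c(O)c1)OCCCCCCO[N+](=O)[O-]`: > 50000 nM

Compound 2 has no number, only > 50000 nM, which is a limit of the assay. Compound 1 likewise shows only a limit. For the measured compounds named here, the series so far sits at the limit of > 50000 nM in this assay, at which 2 of the 2 values shown sit.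

Compound 3 `COc1cc(/C=C/C(=O)OCCCCCCO[N+](=O)[O-])ccc1OCCCCCCO[N+](=O)[O-]` departs from compound 2 by methyl in place of hydrogen on an oxygen on an aromatic ring, hydroxy to methoxy.

No measured step sizes this change, so in this assay no shift beyond the scatter, in either direction, is expected. The estimated step of a number no higher from compound 2 to compound 3 (the limit leaves the size open) is expected to be small. For compound 3 the estimate is 50000 nM, with an expected range of 20000 nM to 100000 nM, most likely reported again as a limit.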

Compound 3, half-maximal inhibitory concentration: > 50000 nM
Compound 3: a limit, no number; the forecaster's own chance of this, stated with the estimate: 85%; the middle value sits exactly at the limit.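

No step from compound 1 or compound 2 to compound 3 can be read, as the series sits entirely at a limit: the limit of > 50000 nM in this assay, at which 3 of the 3 values shown sit.

The compounds shown leave open how far these three actually differ, and whether the methyl or 6-(nitrooxy)hexyl change matters at all.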